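The source may hold more compounds than are shown below. What is called first, only, known or untested is meant among the compounds shown, and "the series" means these compounds.

Compound 1: `CCCCCCCCCC/N=C1/SC[C@@H]2[C@@H](O)[C@H](O)[C@@H](CO)N12` — 93000 nM
Compound 2: `CCCCCCCCNC(=S)N1[C@@H](CO)[C@H](O)[C@@H](O)[C@@H]1CO` — 266000 nM

Of the compounds shown here, two have been measured in an assay for inhibition of beta-galactosidase (Bos taurus), read by spectrophotometry; on this read-out higher numbers stand for weaker inhibition and lower numbers for stronger inhibition. Compound 1 gives the lowest of the two numbers, 93000 nM; compound 2 gives the higher number, 266000 nM, and the gap between the two lies beyond the usual scatter. Going by the values given here, no pair of measured compounds differs in a single place, so no measured step is available to lean on.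

Compound 3, `CCCCCCCCCC/N=C1/SC[C@H]2[C@H](O)[C@@H](O)[C@H](CO)N12`, keeps every atom and bond of compound 1 and differs from it only in configuration: the two compounds have the same atoms and bonds and differ only in configuration as drawn: 4 of 5 stereo elements differ; a stereocentre at a saturated ring carbon is drawn S in compound 1 and R in compound 3; a stereocentre at a saturated ring carbon is drawn R in compound 1 and S in compound 3; a stereocentre at a saturated ring carbon is drawn R in compound 1 and S in compound 3; a stereocentre at a saturated ring carbon is drawn R in compound 1 and S in compound 3. For an inhibitor built on a carbohydrate-like core, inverting the configuration at most of its ring centres is a large change, and the expectation is that compound 3 is a clearly weaker inhibitor than compound 1, with a step of a 6.5-fold higher number from compound 1 to compound 3 (0.81 log units; beyond the scatter) that goes well beyond the scatter. Compound 3 is therefore estimated at 600000 nM, within a range of 150000 nM to 3000000 nM, with a real chance that only an assay limit is reported.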

Compound 3, half-maximal inhibitory concentration: 36000 nM
Compound 3: the middle estimate sits 17-fold (1.22 log units) above what was measured; the measured number lies below the stated range.
By their numbers in this assay, from the lowest: compound 3; then compound 1; then compound 2.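

In this assay, going by these compounds alone, changing configuration alone gives a 2.6-fold lower number from compound 1 to compound 3 (0.41 log units; beyond the scatter), the first measured step in this set, and it shows that the arrangement of the ring centres on the shared core moves the read-out without any atom or bond being exchanged. The direction matters as well: inverting four of the five stereo elements does not cost inhibition, and the configuration drawn in compound 3 is the better of the two on this core. The step can be assigned to configuration and to nothing else, because the structures allow no other difference: the fact that compounds 1 and 3 differ only in the configuration as drawn

Because the four stereocentres change together, the compounds shown cannot tell which of them carries the step, or whether any one inversion alone would move the number. From the compounds shown here alone, it also remains open how a longer chain, or an amine at the end of the decyl chain, would behave on the core of compound 3.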